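Swapping hydroxymethyl for a dihydroxyphenyl ring

This account rests on a few compounds, and the source may have more. Where it says the series, first, only, none or still open, it means among the compounds named here.

In an ADME assay on MT4 cells (Homo sapiens) for cytotoxicity, read by MTT assay (a higher number here means that more compound is tolerated, a lower number that less compound is tolerated), compound 1 `Cc1cc(C)cc(S(=O)(=O)c2c(C(=O)NCc3ccc(O)cc3)[nH]c3ccc(Cl)cc23)c1` gives 6250 nM, while compound 2 `Cc1cc(C)cc(S(=O)(=O)c2c(C(=O)NCc3ccc(CO)cc3)[nH]c3ccc(Cl)cc23)c1` gives 31100 nM, the higher of the two numbers. Compound 3 `Cc1cc(C)cc(S(=O)(=O)c2c(C(=O)NCc3ccc(O)c(O)c3)[nH]c3ccc(Cl)cc23)c1` replaces the 4-(hydroxymethyl)phenyl of compound 2 with 3,4-dihydroxyphenyl: 3,4-dihydroxyphenyl in place of 4-(hydroxymethyl)phenyl on a saturated chain carbon bound to an amide-type nitrogen. For the measured compounds named here, one measured step bears on this change: a 5.0-fold higher number from compound 1 to compound 2 (0.70 log units; beyond the scatter), where hydroxymethyl took the place of hydroxy on an aromatic carbon. Compound 3 returns to hydroxy on aromatic carbon, like compound 1 at 6250 nM, so a reversal of similar size is expected. The estimated change is a 4.8-fold lower number from compound 2 to compound 3 (0.68 log units; beyond the scatter), towards a lower number. For compound 3 the expected value is 6500 nM, within a range of 2200 nM to 20000 nM.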

Compound 3, half-maximal cytotoxic concentration: 18300 nM
Compound 3: the middle estimate sits 2.8-fold (0.45 log units) below what was measured; low and high end bracket the measured number.
By their numbers in this assay, from the lowest: compound 1; then compounds 3 and 2 (each within the scatter of the next).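

In this assay the swap to 3,4-dihydroxyphenyl gives a 1.7-fold lower number from compound 2 to compound 3 (0.23 log units; within the scatter) and so cannot be told apart from 4-(hydroxymethyl)phenyl at this place. Hydroxy in place of hydrogen on an aromatic carbon gives a 2.9-fold higher number from compound 1 to compound 3 (0.47 log units; beyond the scatter) as a step that counts, so having a hydroxy on this ring does not by itself hold the number at the level of compound 1. Open, on these data alone, is how an amine or a carboxylic acid on this ring would read, and whether a longer chain such as hydroxyethyl would match hydroxymethyl. Nothing at hand gives a reason for either step.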